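The compounds below may be only part of what the source reports. "The series", "measured", "known", "first", "only" and "open" are said of these compounds alone.

Among the compounds with values here, in a functional assay on PC-3 cells (Homo sapiens) for cytotoxicity, read by MTT assay, with a stated time of 72 h (on this read-out lower numbers stand for stronger inhibition and higher numbers for weaker inhibition), compound 1 (`COc1ccc(/C=C/C(=O)Nc2cc3c(Nc4ccc(F)c(Cl)c4)ncnc3cc2O[C@H]2CCOC2)c(OC)c1`) gives 2760 nM and compound 2 (`COc1ccc(/C=C/C(=O)Nc2cc3c(Nc4ccc(F)c(Cl)c4)ncnc3cc2O[C@H]2CCOC2)cc1`) gives 2240 nM, so compound 2 stands within the scatter of the only other measured value. Compound 3 (`O=C(/C=C/c1ccc(Br)cc1)Nc1cc2c(Nc3ccc(F)c(Cl)c3)ncnc2cc1O[C@H]1CCOC1`) follows from compound 2 with bromo in place of methoxy on an aromatic carbon. Within the data shown here, the one measured step, a 1.2-fold lower number from compound 1 to compound 2 (0.09 log units; within the scatter), swaps hydrogen for methoxy and offers thin guidance for bromo. On that basis, no step beyond the scatter is expected in this assay. The expected step is a 1.1-fold lower number from compound 2 to compound 3 (0.05 log units; within the scatter). Compound 3 is estimated at 2000 nM, with a range of 800 nM to 5500 nM.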

Compound 3, half-maximal inhibitory concentration: 28200 nM
For compound 3 the middle estimate is 14-fold (1.15 log units) below the measured one; measured number outside the range, above it.
By their numbers in this assay, from the lowest: compounds 2 and 1 (each within the scatter of the next); then compound 3.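

Within the data shown here, this position, para to a large group, is the first place where a single change moves the number beyond the scatter: bromo in place of methoxy gives a 13-fold higher number from compound 2 to compound 3 (1.10 log units; beyond the scatter) in this assay. Replacing 2,4-dimethoxyphenyl with 4-bromophenyl points the same way, with a 10-fold higher number from compound 1 to compound 3 (1.01 log units; beyond the scatter), so the methoxy at this position tolerates loss far less well than the scatter-level step between compound 1 and compound 2 suggested. Nothing available explains the change. As far as these compounds go, whether the rise follows from bromo entering or from methoxy leaving stays open. Hydrogen, chloro or an amine at this position could separate the two.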